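A small fluorinated ring in place of a propyl chain

The compounds below may be only part of what the source reports. "The series", "measured", "known", "first", "only" and "open" are said of these compounds alone.

Three compounds have been measured in an assay on SH-EP1 cells for agonist activity at Neuronal acetylcholine receptor; alpha4/beta2 (Homo sapiens), read by FLIPR and calcium flux; on this read-out higher numbers stand for an effect only at larger amounts of compound and lower numbers for an effect already at smaller amounts:
compound 1 `CCCC(=O)N1CC2CC(C1)N2` gives 850 nM;
compound 2 `O=C(C1CC=CC1)N1CC2CC(C1)N2` gives 17000 nM;
compound 3 `O=C(CC1C=CCC1)N1CC2CC(C1)N2` gives 37000 nM.

Compound 1 thus shows the lowest number of the three, with compound 2 and compound 3 both clearly weaker. Compound 4 `O=C([C@H]1C[C@@H]1F)N1CC2CC(C1)N2` differs from compound 1 by 2-fluorocyclopropyl in place of propyl on a carbonyl carbon. Going by the values given here, the one measured step that bears on this is a 44-fold higher number from compound 1 to compound 3 (1.64 log units; beyond the scatter), where a ring entered the chain on the carbonyl side and the number rose sharply. A rise is therefore expected for compound 4 as well, though the three-membered ring here is a smaller change than in compound 3, so a more moderate step a 2.9-fold higher number from compound 1 to compound 4 (0.47 log units; beyond the scatter) is estimated. Compound 4 is expected to give about 2500 nM, within a range of 600 nM to 10000 nM.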

Compound 4, half-maximal effective concentration: 2800 nM
Estimate against measurement, compound 4: 1.1-fold (0.05 log units) below; measured number inside the range.
By their numbers in this assay, from the lowest: compound 1; then compound 4; then compound 2; then compound 3.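

With 2-fluorocyclopropyl on the carbonyl carbon, the rise is a 3.3-fold higher number from compound 1 to compound 4 (0.52 log units; beyond the scatter), far smaller than the rise of a 44-fold higher number from compound 1 to compound 3 (1.64 log units; beyond the scatter), so a ring at this position can be tolerated much better than the earlier result suggested. Even so, propyl keeps the lowest number, and none of the rings shown improves on it. Nothing here explains the difference between these groups.

Plain cyclopropyl would show whether the ring or the fluorine drives the rise. From the compounds shown here alone, whether a longer chain such as pentyl would lower the number also remains open.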